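Replacing the Aryl Group of Compound 1

The compounds below may be only part of what the source reports. "The series", "measured", "known", "first", "only" and "open" are said of these compounds alone.

In a functional assay on MCF7 cells (Homo sapiens) for inhibition, read by MTT assay, with a stated time of 72 h, tested at 30 uM (a lower number here means less inhibition of growth, a higher number more inhibition of growth at the concentration tested), compound 1 (`C=CCc1ccc(OCc2cn(-c3ccccc3Cl)nn2)c(O)c1`) gives 58.3% and compound 2 (`C#CCOc1ccc(CC=C)cc1O`) gives 23.7% under the same conditions. Compound 1 therefore stands as the higher of the two, with a gap beyond the usual scatter.

Compound 3 (`C=CCc1ccc(OCc2cn(-c3cccc(C#N)c3)nn2)c(O)c1`) has 3-cyanophenyl in place of 2-chlorophenyl on an aromatic nitrogen and is otherwise the same as compound 1. For the measured compounds named here, no measured pair shows what a change at this place does, so the expectation remains cautious and starts from compound 1 at 58.3% in this assay as its only anchor. The expected change is a small fall that stays within the scatter, with an estimated a number 8.3 percentage points lower from compound 1 to compound 3 (within the scatter) in this reading. Compound 3 is estimated at 50% with an expected range from 30% to 68% in this measurement.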

Compound 3, percent growth inhibition at one concentration: 31.9%
Compound 3: middle estimate off by 18.1 percentage points, on the high side; measured number inside the range.
By their numbers in this assay, from the lowest: compounds 2 and 3 (each within the scatter of the next); then compound 1.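

For the compounds shown here, compound 3 gives the first reading of a change on the aromatic nitrogen of the five-membered ring: in this assay, 3-cyanophenyl in place of 2-chlorophenyl gives a number 26.4 percentage points lower from compound 1 to compound 3 (beyond the scatter). The inhibition of growth at the concentration tested therefore depends on which substituted phenyl group stands at this place, even though both groups keep the same six-membered aromatic ring of carbon. No measurement at hand bears on why the number falls.

The step replaces the chlorine with a nitrile and also changes the number in the group's name, so it cannot say which of the two differences matters. The compounds shown leave open how 2-cyanophenyl, 3-chlorophenyl or plain phenyl would read at this place, and whether any group here could reach or pass compound 1.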